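The source may hold more compounds than are shown below. What is called first, only, known or untested is meant among the compounds shown, and "the series" means these compounds.

Compounds measured in an ADME assay on Huh-7 cells (Homo sapiens) for cytotoxicity, read by XTT assay; on this read-out lower numbers stand for higher toxicity in this test and higher numbers for lower toxicity in this test:
- compound 1 `[N-]=[N+]=N[C@H]1C[C@H](n2cc(Cl)c(=O)[nH]c2=O)O[C@@H]1CO`: > 100 ug/mL
- compound 2 `[N-]=[N+]=N[C@H]1C[C@H](n2cc(Br)c(=O)[nH]c2=O)O[C@@H]1CO`: > 100 ug/mL

The value of compound 1 in this assay is a limit of the assay, not a number. The value of compound 2 in this assay is likewise a limit. The step that the two limits leave unreadable from compound 1 to compound 2 is therefore unreadable, since both ends rest on (the limit of > 100 ug/mL in this assay, at which 2 of the 2 values shown sit). Among the measured compounds shown here, compound 2 thus stands only at that limit, with no number of its own; the one other value shown is a limit as well.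

Compound 3 `[N-]=[N+]=N[C@H]1C[C@H](n2cc(F)c(=O)[nH]c2=O)O[C@@H]1CO` differs from compound 2 by fluoro in place of bromo on an aromatic carbon. For the measured compounds named here, the only measured step, from chloro to bromo at the same carbon, gave no readable size, so no direction can be taken from it for the change to fluoro. The expectation is that compound 3 again reaches the limit in this assay, with an estimated value of 150 ug/mL (range 60 ug/mL to 400 ug/mL), which means an expected step that the limit leaves unreadable from compound 2 to compound 3 not beyond the scatter.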

Compound 3, half-maximal cytotoxic concentration: > 100 ug/mL
Compound 3: only a limit was reported; the forecaster's own chance of this, stated with the estimate: 85%; the middle value is on the limit's open side.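

In this assay compound 3 gives > 100 ug/mL, a limit of the assay and not a number. Among the compounds shown here, no step among compound 1, compound 2 and compound 3 can be read, since all three rest on one limit: the limit of > 100 ug/mL in this assay, at which 3 of the 3 values shown sit. The compounds shown leave open whether chloro, bromo and fluoro differ at all in this assay.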